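The source may hold more compounds than are shown below. What is called first, only, known or untested is meant among the compounds shown, and "the series" means these compounds.

Measured compounds:

Compound 1 `C=C1C[C@]23C[C@@]1(O)CC[C@@H]2c1cccc(C)c1[C@@H]3Cn1cc(-c2ccc(OC)cc2)nn1`: in a functional assay on MCF7 cells (Homo sapiens) for cytotoxicity, read by MTT assay, with a stated time of 4 days (on this read-out lower numbers stand for stronger inhibition and higher numbers for weaker inhibition), compound 1 gives > 20000 nM, which is a limit of the assay and not a number.
Compound 2 `C=C1C[C@]23C[C@@]1(O)CC[C@H]2c1cc(Br)c(O)c(C)c1[C@@H]3Cn1cc(-c2ccc(OC)cc2)nn1`: in this assay compound 2 gives > 20000 nM, again a limit.
Compound 3 `C=C1C[C@]23C[C@@]1(O)CC[C@H]2c1ccc(O)c(C)c1[C@@H]3Cn1cc(-c2ccc(OC)cc2)nn1`: in this assay compound 3 gives > 20000 nM, again a limit.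

Compound 2 therefore stands at the limit of > 20000 nM in this assay, at which 3 of the 3 values shown sit, so its position within the series cannot be placed more closely. Going by the values given here, the one step that differs in a single place, a step that the two limits leave unreadable from compound 2 to compound 3, is hydrogen in place of bromo on an aromatic carbon, and its size cannot be read from two limits.

Compound 4 `C=C1C[C@]23C[C@@]1(O)CC[C@H]2c1cc(Br)c(O)c(C)c1[C@@H]3Cn1cc(-c2ccc(Cl)cc2)nn1` differs from compound 2 by chloro in place of methoxy on an aromatic carbon of a six-membered aromatic ring of carbon only, para to a large group. Among the compounds with values here, no measured step touches this position, and every value so far is a limit, so no direction or size can be drawn from the data. The expectation is that compound 4 stays at the limit, with an estimated step that the limit leaves unreadable from compound 2 to compound 4. Compound 4 is estimated at 30000 nM, range 8000 nM to 120000 nM.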

Compound 4, half-maximal inhibitory concentration: 10200 nM
The estimate for compound 4 lay 2.9-fold (0.47 log units) above the measured number, and the stated range covers the measured number.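

Changing 4-methoxyphenyl to 4-chlorophenyl gives an at least 1.9-fold lower number from compound 2 to compound 4 (0.29 log units; that floor lies within the scatter) in this assay. This makes the aromatic carbon para to a large group the first position in the series where a single change is tied to a measured number rather than a limit, although the printed floor of the step does not go beyond the scatter. The true size and firmness of the step stay unresolved, as compound 2 and the other earlier compounds offer only a limit for comparison: the limit of > 20000 nM in this assay, at which 3 of the 4 values shown sit.

On these data alone, it remains open whether an amine, a carboxylic acid or a fluoro group at this place would give a lower or a higher number than chloro. As far as these compounds go, it is also open whether the number for compound 4 would hold with hydrogen in place of bromo on the other aromatic carbon.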